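Adding a Chloro Group Beside a Trifluoromethyl Amide

This account rests on a few compounds, and the source may have more. Where it says the series, first, only, none or still open, it means among the compounds named here.

Compound 1, `COc1ccc(C(=O)Nc2cccc(-c3ccnc4c(N)cccc34)c2)cc1OC`, gives 9500 nM in a functional assay on A375P cells (Homo sapiens) for antiproliferative activity, read by MTT assay, with a stated time of 48 h; a higher number here means a weaker inhibitor, a lower number a stronger inhibitor.
Compound 2, `Cc1cc(C(=O)Nc2cccc(-c3ccnc4c(N)cccc34)c2)ccc1Br`, gives 9900 nM in this assay.
Compound 3, `Nc1cccc2c(-c3cccc(NC(=O)c4cccc(C(F)(F)F)c4)c3)ccnc12`, gives 7900 nM in this assay.

These three compounds share one core and differ only in the aryl group attached to the carbonyl carbon. Compound 3 carries the lowest of the three numbers, yet its separation from the others is small: a 1.2-fold lower number from compound 1 to compound 3 (0.08 log units; within the scatter) and a 1.3-fold lower number from compound 2 to compound 3 (0.10 log units; within the scatter), both within the scatter. The remaining pair behaves the same way, with a 1.0-fold higher number from compound 1 to compound 2 (0.02 log units; within the scatter). So far, then, exchanging the whole aryl group has not moved the number beyond what repeated measurement would produce on its own.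

Compound 4, `Nc1cccc2c(-c3cccc(NC(=O)c4cc(Cl)cc(C(F)(F)F)c4)c3)ccnc12`, keeps the aryl group of compound 3 and differs from it by chloro in place of hydrogen on an aromatic carbon, the new group sitting meta to a trifluoromethyl group. Within the data shown here, no measured step adds a single substituent to an otherwise unchanged aryl; the steps available all swap the aryl group entirely and all stay within the scatter. On that basis no step beyond the scatter is expected in this assay in either direction. Compound 4 is therefore expected to give 7000 nM, with a range from 3000 nM to 16000 nM. The expected step is a 1.1-fold lower number from compound 3 to compound 4 (0.05 log units; within the scatter).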

Compound 4, half-maximal inhibitory concentration: 18500 nM
For compound 4 the middle estimate is 2.6-fold (0.42 log units) below the measured one; measured number above the stated range.
By their numbers in this assay, from the lowest: compounds 3, 1, 2 and 4 (each within the scatter of the next, the first and the last beyond it).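

Adding a single chloro on an aromatic carbon, meta to a trifluoromethyl group, gives the first step in this assay that lies beyond the scatter, a 2.3-fold higher number from compound 3 to compound 4 (0.37 log units; beyond the scatter), and it runs toward a weaker inhibitor. The exchanges of the whole aryl group among compound 1, compound 2 and compound 3 all stayed within the scatter, whereas this one added heavy atom on an otherwise unchanged aryl group does not, so the number does respond to a change at this position, though the step is modest and rests on a single pair. No supporting evidence bears on why the number moves.

Going by these compounds, whether the step belongs to chloro itself or would follow any substituent at this position stays open, and a fluoro, a methyl, a methoxy or an amine on the same carbon would separate those readings. On these data alone, it also stays open whether the step would persist with a nitrile in place of the trifluoromethyl group, or with chloro added to the aryl groups of compound 1 and compound 2.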